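The source may hold more compounds than are shown below. What is called first, only, known or untested is meant among the compounds shown, and "the series" means these compounds.

The measured compounds in an ADME assay on HaCaT cells (Homo sapiens) for cytotoxicity, read by MTT assay, with a stated time of 72 h (on this read-out higher numbers stand for weaker inhibition and lower numbers for stronger inhibition), are:

compound 1, `Cc1cc(S(=O)(=O)/N=C(\N)n2nccc2-c2ccccc2)c(SCc2ccc(Cl)cc2)cc1Cl`, giving 12000 nM
compound 2, `Cc1cc(S(=O)(=O)/N=C(\N)n2nccc2-c2ccccc2)c(SCc2ccccc2Cl)cc1Cl`, giving 20000 nM
compound 3, `Cc1cc(S(=O)(=O)/N=C(\N)n2nccc2-c2ccccc2)c(SCc2ccccc2C)cc1Cl`, giving 18000 nM

Compound 2 holds the highest of the three numbers, yet nothing separates it from its neighbours: the step of a 1.1-fold lower number from compound 2 to compound 3 (0.05 log units; within the scatter) is the nearest, and the step of a 1.7-fold higher number from compound 1 to compound 2 (0.22 log units; within the scatter), from the compound furthest away, is also within the scatter. Compound 4, `Cc1ccc(CSc2cc(Cl)c(C)cc2S(=O)(=O)/N=C(\N)n2nccc2-c2ccccc2)cc1`, differs from compound 2 in one place: 4-methylphenyl in place of 2-chlorophenyl on a saturated chain carbon bound to a sulfur.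

Among the measured compounds shown here, three measured steps bear on this change. The step of a 1.7-fold higher number from compound 1 to compound 2 (0.22 log units; within the scatter) and the step of a 1.5-fold higher number from compound 1 to compound 3 (0.18 log units; within the scatter) each move the same group on the saturated chain carbon bound to the sulfur, and the step of a 1.1-fold lower number from compound 2 to compound 3 (0.05 log units; within the scatter) swaps chloro for methyl on an aromatic carbon; all three lie within the scatter. On that basis no step beyond the scatter in this assay is expected for compound 4. The estimated step is a 1.4-fold lower number from compound 2 to compound 4 (0.15 log units; within the scatter), and compound 4 is expected to give 14000 nM, within a range of 7000 nM to 28000 nM.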

Compound 4, half-maximal inhibitory concentration: 20000 nM
Beside the measured number, compound 4's estimate is 1.4-fold (0.15 log units) below it; the measured number falls inside the stated range.
By their numbers in this assay, from the lowest: compounds 1, 3, 2 and 4 (each within the scatter of the next).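

In this assay, the place on a saturated chain carbon bound to a sulfur now holds a fourth group, and it still gives no step beyond the scatter: 4-methylphenyl in place of 2-chlorophenyl gives no change at the digits printed from compound 2 to compound 4 (within the scatter), and 4-methylphenyl in place of 2-methylphenyl gives a 1.1-fold higher number from compound 3 to compound 4 (0.05 log units; within the scatter). Methyl in place of chloro on an aromatic carbon can now be read on a second pair, with a 1.7-fold higher number from compound 1 to compound 4 (0.22 log units; within the scatter). That change can thus be set side by side on two cores, and the two readings do not separate: the same change on two cores in this assay, a 1.1-fold lower number (0.05 log units; within the scatter) from compound 2 to compound 3 and a 1.7-fold higher number (0.22 log units; within the scatter) from compound 1 to compound 4, 1.9-fold (0.27 log units) apart, within the scatter of two such steps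

Going by these compounds, all four groups at this place are chloro- or methyl-bearing phenyl rings, so what remains open is whether any other kind of group there would move the number beyond the scatter. A carboxylic acid or an amine on that ring, or a longer chain in place of the benzyl, would address this.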